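The compounds below may be only part of what the source reports. "The series", "measured", "known", "first", "only" and "open" are said of these compounds alone.

Measured compounds:
- compound 1, `Cc1ccc(-c2nn(-c3ccccc3)cc2C(=O)NOCc2ccccc2F)cc1`; in an ADME assay on HEK-293T cells (Homo sapiens) for antiproliferative activity, read by MTT assay, with a stated time of 48 h, in the presence of a further agent that is not named here (on this read-out lower numbers stand for higher toxicity in this test and higher numbers for lower toxicity in this test), compound 1 gives 20600 nM
- compound 2, `COc1ccc(-c2nn(-c3ccccc3)cc2C(=O)NOCc2ccccc2)cc1`; in this assay compound 2 gives 201000 nM

Compound 2 stands at the higher number of the two, and the gap from compound 1 to compound 2 lies beyond the scatter. The two differ in more than one place, so the values show only that much and nothing about either part alone.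

Compound 3, `COc1ccc(-c2nn(-c3ccccc3)cc2C(=O)NOCc2ccccc2F)cc1`, is not yet measured. It is reached from compound 2 by fluoro in place of hydrogen on an aromatic carbon. For the measured compounds named here, no step between measured compounds differing in a single place covers this change. Compound 1 carries the same 2-fluorobenzyl group together with a methyl group, and its lower number of 20600 nM cannot be split between the two parts.

For compound 3 in this assay a step toward a lower number is expected, a 1.8-fold lower number from compound 2 to compound 3 (0.26 log units; within the scatter), of modest size and possibly not beyond the scatter. Compound 3 is estimated at 110000 nM, with a range from 35000 nM to 300000 nM.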

Compound 3, half-maximal cytotoxic concentration: 24600 nM
Compound 3: the middle estimate sits 4.5-fold (0.65 log units) above what was measured; measured number below the stated range.
By their numbers in this assay, from the lowest: compounds 1 and 3 (each within the scatter of the next); then compound 2.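

In this assay, fluoro in place of hydrogen on an aromatic carbon, ortho to a large group, turning benzyloxy into (2-fluorobenzyl)oxy, gives an 8.2-fold lower number from compound 2 to compound 3 (0.91 log units; beyond the scatter), so this single change is enough for a step beyond the scatter toward higher toxicity in this test. With the 2-fluorobenzyl group held constant, methoxy in place of methyl gives a 1.2-fold higher number from compound 1 to compound 3 (0.08 log units; within the scatter), which stays within the scatter and shows no separate contribution from that change. Nothing measured here offers an explanation for either step.

The compounds shown leave open whether chloro or an amine on the same aromatic carbon would give a step of similar size. They also leave open whether the fluoro step would hold with methyl in place of methoxy, as the benzyl counterpart of compound 1 is absent from this set.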